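The source may hold more compounds than are shown below. What is called first, only, known or untested is meant among the compounds shown, and "the series" means these compounds.

Compound 1 `CNc1nccc2c1ncn2C1O[C@H](CO)[C@@H](O)[C@H]1O`: 8%
Compound 2 `CC1OC(n2cnc3c(N)nccc32)CC1O`: 3%

In a functional assay (Homo sapiens) for inhibition of Nucleic Acid, tested at 100 uM (on this read-out lower numbers stand for less inhibition and higher numbers for more inhibition at the one concentration tested (going by the name of the read-out)), compound 1 gives 8%, and compound 2 gives 3%; the two values lie within the scatter of each other, so neither compound is separated from the other, and both show little inhibition. Compound 3 `CCNc1nccc2c1ncn2C1O[C@H](CO)[C@@H](O)[C@H]1O` is not yet measured. It differs from compound 1 in one place: methyl in place of hydrogen on a saturated chain carbon bound to a nitrogen on an aromatic ring. Among the measured compounds shown here, no measured pair shows such a change, so its effect is unknown. With compound 1 at 8%, compound 3 is expected to stay close, a step of no change at the digits printed from compound 1 to compound 3 (within the scatter), within the scatter. Compound 3 is estimated at 8%, between -5% and 22%.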

Compound 3, a percentage reported as inhibition, at one concentration (the size of the read-out at that concentration, not a potency): 4%
Estimate against measurement, compound 3: 4 percentage points above; the range from low to high includes it.
By their numbers in this assay, from the lowest: compounds 2, 3 and 1 (each within the scatter of the next).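

In this assay, among the compounds shown here, the change from methylamino to ethylamino gives a number 4 percentage points lower from compound 1 to compound 3 (within the scatter), the first single-place comparison. At this position, the added methyl leaves compound 3 unseparated from compound 1, and both show little inhibition. Nothing available explains this result. On these data alone, it remains open whether a longer chain, such as propyl or butyl, or a carboxylic acid at the end of the chain would move the read-out beyond the scatter. One step also cannot show how other groups at this position would behave.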